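Thiophene in Place of Nitrophenyl on an Amide Carbonyl

A few compounds are considered here, and "the series" means these few. Any claim that something is new, unique, unknown or untested is made for them only; others in the source may bear on it.

Measured compounds:
compound 1, `COc1ccc(S(=O)(=O)N2CCc3cccc(NC(=O)c4ccc([N+](=O)[O-])cc4)c32)cc1`, 116 nM
compound 2, `COc1ccc(S(=O)(=O)N2CCc3cccc(NCc4ccccc4)c32)cc1`, > 10000 nM

Of the compounds shown here, two have been tested in a functional assay on TSGH 9201 cells (Homo sapiens) for cytotoxicity; a lower number here means a stronger inhibitor, a higher number a weaker inhibitor. For the measured compounds named here, compound 1 gives 116 nM, the only outright number in the set. Compound 2 returns only a limit of the assay, > 10000 nM, so its value is not a number but a boundary (the limit of > 10000 nM in this assay, at which 1 of the 2 values shown sits). Going by the values given here, the two structures differ in more than one place, so no single step can be drawn between them; the two values simply show that compound 1 is measurable where compound 2 is not.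

Compound 3, `COc1ccc(S(=O)(=O)N2CCc3cccc(NC(=O)c4cccs4)c32)cc1`, has not yet been measured in this assay. It differs from compound 1 by thiophen-2-yl in place of 4-nitrophenyl on a carbonyl carbon whose other neighbour is an amide-type nitrogen. Among the compounds with values here, with no measured step of this kind to lean on, the size and direction of the change can only be guessed. The account expects the step from compound 1 to compound 3 in this assay, a 4.3-fold higher number from compound 1 to compound 3 (0.63 log units; beyond the scatter), to be a modest loss, probably beyond the scatter but not a collapse to the limit. Compound 3 is therefore expected to give about 500 nM, within a range of 100 nM to 4000 nM.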

Compound 3, half-maximal inhibitory concentration: 54 nM
Compound 3: middle estimate off by 9.3-fold (0.97 log units), on the high side, and the stated range ends above it.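

In this assay, the 4-nitrophenyl on the carbonyl carbon of compound 1 proves replaceable: thiophen-2-yl in its place gives a 2.1-fold lower number from compound 1 to compound 3 (0.33 log units; beyond the scatter), so a five-membered aromatic ring with one sulfur atom is at least as well accepted here, and the nitro group is not needed for a value of this order. For the compounds shown here, compound 3 also supplies the first single-place comparison with compound 2, with (thiophen-2-yl)carbonyl in place of benzyl on a nitrogen on an aromatic ring giving an at least 180-fold lower number from compound 2 to compound 3 (2.26 log units; beyond the scatter), so what sits on that nitrogen matters far more in this set than the swap of one ring on the carbonyl carbon for another. The size of that larger step is only a bound, as the value of compound 2 is a limit of the assay and not a number: the limit of > 10000 nM in this assay, at which 1 of the 3 values shown sits.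

The compounds shown leave open how an unsubstituted phenyl, a furan-2-yl or a thiophen-3-yl group would fare on the same carbonyl carbon. They also do not separate the carbonyl from the ring in the larger step, which a thiophen-2-ylmethyl or a benzoyl group on that nitrogen would do.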